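The source may hold more compounds than are shown below. What is called first, only, known or untested is meant among the compounds shown, and "the series" means these compounds.

In a functional assay on MT4 cells (Homo sapiens) for cytotoxicity (a higher number here means a weaker inhibitor, a lower number a stronger inhibitor), compound 1 `Cc1cc(C)cc(Sc2cccc(N)c2C#N)c1` reaches only the limit of > 2000 nM. Compound 2 `COc1cc(C)cc(Sc2cccc(N)c2C#N)c1` gives 10000 nM. Compound 3 `COc1ccc([S+]([O-])c2cccc(N)c2C#N)cc1` likewise reaches only the limit of > 200000 nM. From compound 2 to compound 1 the change is methyl in place of methoxy on an aromatic carbon, and the step that the limit leaves unreadable from compound 2 to compound 1 cannot be read because of the limit of > 2000 nM in this assay, at which 1 of the 3 values shown sits. How the core of compound 3 differs from the core of compound 2 is not broken down here. Compound 4 `Cc1ccc([S+]([O-])c2cccc(N)c2C#N)cc1` is not yet measured. From compound 3 to compound 4 the change is methyl in place of methoxy on an aromatic carbon, the same kind of change, yet the place differs: para to a large group rather than meta to a large group and meta to a methyl group. The step expected for a number no higher from compound 3 to compound 4 (the limit leaves the size open) rests on compound 3 sitting at the limit of > 200000 nM in this assay, at which 1 of the 3 values shown sits, so little shift is expected. Compound 4 is therefore estimated at 200000 nM.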

Compound 4, half-maximal inhibitory concentration: > 200000 nM
Compound 4: only a limit was reported; the forecaster's own chance of this, stated with the estimate: 75%; the middle value sits exactly at the limit.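

Compound 3 and compound 4 both stand only at a limit, so no step between them can be read: the limit of > 200000 nM in this assay, at which 2 of the 4 values shown sit.

The compounds shown leave open whether methyl in place of methoxy shifts the value at all in this assay.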